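Methyl Substitution on the Aryl Ring: An Expected Outcome

This account rests on a few compounds, and the source may have more. Where it says the series, first, only, none or still open, it means among the compounds named here.

Measured so far in an assay on CHO cells for displacement of a labelled ligand from histamine receptor H3 (Macaca mulatta); a lower number here means a stronger inhibitor, a higher number a weaker inhibitor:
Compound 1, `CC(=O)N1CCCC1C(=O)Nc1ccc(N2CCC(N3CCCC3C)C2)c(C)c1`, gives 44.9 nM.
Compound 2, `CC1CCCN1C1CCN(c2ccc(NC(=O)C3CC3)cc2)C1`, gives 9.7 nM.

Of the two numbers, compound 2 has the lower one, and its gap to compound 1 lies beyond the scatter of repeated measurements. The two compounds differ in more than one place, so their two values alone cannot be traced to a single change.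

Compound 3, `Cc1cc(NC(=O)C2CC2)ccc1N1CCC(N2CCCC2C)C1`, has not yet been measured. It differs from compound 2 by methyl in place of hydrogen on an aromatic carbon. Among the measured compounds shown here, no pair of measured compounds shows the effect of this change on its own, so there is no step to lean on. The remaining shared parts of compound 2 and compound 3 are the same, and a single added methyl on the aromatic ring is a small change. An expectation of little movement, or a modest weakening within or just beyond the scatter, seems the most defensible; the step from compound 2 to compound 3 is expected to be a 1.4-fold higher number from compound 2 to compound 3 (0.16 log units; within the scatter). For compound 3 in this assay the estimate is 14 nM, expected to fall between 5 nM and 40 nM.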

Compound 3, inhibition constant: 17.7 nM
Beside the measured number, compound 3's estimate is 1.3-fold (0.10 log units) below it; low and high end bracket the measured number.
By their numbers in this assay, from the lowest: compounds 2 and 3 (each within the scatter of the next); then compound 1.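

In this assay, methyl in place of hydrogen on this aromatic carbon, ortho to a large group and meta to a (cyclopropylcarbonyl)amino group, gives a 1.8-fold higher number from compound 2 to compound 3 (0.26 log units; within the scatter), so the added methyl has no effect here that can be told from the scatter. Compound 3 also gives compound 1 its first partner that differs in one place: with the methyl present in both, cyclopropyl in place of 1-acetylpyrrolidin-2-yl on the carbonyl carbon gives a 2.5-fold lower number from compound 1 to compound 3 (0.40 log units; beyond the scatter), a modest step that, unlike the methyl step, lies beyond the scatter.

The compounds shown leave open whether this aromatic carbon would tolerate anything other than hydrogen or methyl, such as a chlorine atom, a methoxy group or an amine, and whether a longer chain or a carboxylic acid on the carbonyl carbon would move the number further in either direction. No measurement offered here explains either step, so the reason for each remains unknown.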